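This account rests on a few compounds, and the source may have more. Where it says the series, first, only, none or still open, it means among the compounds named here.

Compound 2 `Cc1cc(Nc2cc(N3CCN(C)CC3)nc(Nc3ccc(C#N)cc3)n2)n[nH]1` stands as the stronger of the two measured entries in a functional assay on HCT-116 cells (Homo sapiens) for antiproliferative activity, read by CCK-8 assay, with a stated time of 72 h (a higher number here means a weaker inhibitor, a lower number a stronger inhibitor), where compound 2 gives 650 nM. Among the measured compounds shown here, the only other measured compound, compound 1 `Cc1cc(Nc2cc(N3CCN(C)CC3)nc(Nc3ccc(Cl)cc3)n2)n[nH]1`, gives 1370 nM in this assay, and the step of a 2.1-fold lower number from compound 1 to compound 2 (0.32 log units; beyond the scatter) is the single measured change. Compound 3 `COc1ccc(Nc2nc(Nc3cc(C)[nH]n3)cc(N3CCN(C)CC3)n2)cc1` carries the change (methoxy in place of cyano on an aromatic carbon). For the measured compounds named here, the one measured step bears on this only loosely: it shows that exchanging the group on this aromatic carbon moves the number by a modest amount, but no measured pair contains a methoxy, so the direction for compound 3 is unsettled. With the cyano gone, the number for compound 3 is expected to drift back toward that of compound 1 rather than fall further. Compound 3 is therefore estimated at 1200 nM, with a range of 500 nM to 3000 nM. This estimate means an expected step of a 1.8-fold higher number from compound 2 to compound 3 (0.27 log units; within the scatter).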

Compound 3, half-maximal inhibitory concentration: 2240 nM
Estimate against measurement, compound 3: 1.9-fold (0.27 log units) below; measured number inside the range.
By their numbers in this assay, from the lowest: compound 2; then compounds 1 and 3 (each within the scatter of the next).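

In this assay, methoxy in place of cyano on this aromatic carbon, para to a large group, gives a 3.4-fold higher number from compound 2 to compound 3 (0.54 log units; beyond the scatter), so this exchange moves the number beyond the scatter. Methoxy in place of chloro gives a 1.6-fold higher number from compound 1 to compound 3 (0.21 log units; within the scatter), which leaves those two groups unresolved here and makes the cyano of compound 2 the only group of the three set apart from the others. Nothing measured explains why the cyano stands apart, and no supporting evidence bears on this result.

Still open, from the compounds shown here alone, is whether another group on this carbon, such as a primary amide, a carboxylic acid or an amine, matches or passes compound 2. Also open, going by these compounds, is whether the separation of cyano from methoxy persists when the rest of the shared core changes.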